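A few compounds are considered here, and "the series" means these few. Any claim that something is new, unique, unknown or untested is made for them only; others in the source may bear on it.

Compound 2 `O=C(CCc1ccc(C(F)(F)F)cc1)Nc1ccc2nc(N3CC4CC3CN4)ccc2c1` gives 210 nM in an assay on isolated protein for displacement of a labelled ligand from melanin-concentrating hormone receptor 1 (Homo sapiens) (a lower number here means a stronger inhibitor, a higher number a weaker inhibitor), the highest of the two numbers recorded, whereas compound 1 `CC(C)N(C)c1ccc2cc(NC(=O)CCc3ccc(C(F)(F)F)cc3)ccc2n1` gives 2 nM. Within the data shown here, the single measured step, a 110-fold higher number from compound 1 to compound 2 (2.02 log units; beyond the scatter), was large. Compound 3 `CCCN(CCC)c1ccc2cc(NC(=O)CCc3ccc(C(F)(F)F)cc3)ccc2n1` is the unmeasured partner: a group of 7 heavy atoms (6 carbon, 1 nitrogen; no ring) in place of a group of 7 heavy atoms (5 carbon, 2 nitrogen; 2 five-membered non-aromatic rings with 1 hetero atom each), on an aromatic carbon. This change undoes the ring-bearing amine that accompanied the large rise, so a substantial fall in this assay is expected, of about a 70-fold lower number from compound 2 to compound 3 (1.85 log units; beyond the scatter). Compound 3 is therefore estimated at 3 nM, within a range from 1 nM to 15 nM.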

Compound 3, half-maximal inhibitory concentration: 490 nM
Beside the measured number, compound 3's estimate is 160-fold (2.21 log units) below it; measured number above the stated range.
By their numbers in this assay, from the lowest: compound 1; then compound 2; then compound 3.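

Replacing isopropyl(methyl)amino with dipropylamino gives a 250-fold higher number from compound 1 to compound 3 (2.39 log units; beyond the scatter) in this assay, so at this position, next to the ring nitrogen, an open-chain amine does not by itself secure a low number. Replacing the ring-bearing group with dipropylamino, also of 7 heavy atoms, gives a 2.3-fold higher number from compound 2 to compound 3 (0.37 log units; beyond the scatter), so losing the rings does not bring the number down. Nothing available explains either step. The compounds shown leave open where diethylamino would fall, and whether a single pyrrolidine ring would track the open chains or compound 2.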